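Terminal alkyne replacing aryl bromide on the sulfonamide

The compounds below may be only part of what the source reports. "The series", "measured", "known", "first", "only" and "open" are said of these compounds alone.

Compound 1 `CC(=O)Nc1nc(-c2cccc(NS(=O)(=O)c3ccc(Br)cc3)c2)cs1` carries a bromo group on the aryl sulfonamide. In a functional assay on A-375 cells (Homo sapiens) for antiproliferative activity, read by trypan blue exclusion, with a stated time of 48 h, tested at 10 uM (on this read-out lower numbers stand for a stronger effect and higher numbers for a weaker effect at the one concentration tested), compound 1 gives 25.6%, the highest of the two numbers shown here. Compound 2 `CC(=O)Nc1nc(-c2cccc(NS(=O)(=O)c3ccc(C#CC4CCCCC4)cc3)c2)cs1` gives 1.2% in this assay. Compound 3 `CCCCCCCCC#Cc1ccc(S(=O)(=O)Nc2cccc(-c3csc(NC(C)=O)n3)c2)cc1` reaches only a limit of this assay, < 1%, which is the limit of < 1% in this assay, at which 1 of the 3 values shown sits. The two measured steps that touch compound 1 are a number 24.4 percentage points lower from compound 1 to compound 2 (beyond the scatter) and a number at least 24.6 percentage points lower from compound 1 to compound 3 (beyond the scatter); both show that exchanging the bromo group for an alkyne-bearing substituent moves the number far down. Between the two alkynes the difference is a number at least 0.2 percentage points lower from compound 2 to compound 3 (that floor lies within the scatter).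

Compound 4 `C#Cc1cccc(S(=O)(=O)Nc2cccc(-c3csc(NC(C)=O)n3)c2)c1` is not yet measured. Its change from compound 1 is 3-ethynylphenyl in place of 4-bromophenyl on a sulfonyl sulfur. The substituent that enters is again a triple bond outside the aromatic ring, as in compound 2 and compound 3, but it is a bare ethynyl group rather than the cyclohexyl- or octyl-capped alkynes. The two measured steps therefore point towards a drop, though of uncertain size. Compound 4 is expected to give about 12% in this assay, within a range from 2% to 32%. That estimate corresponds to an expected step of a number 13.6 percentage points lower from compound 1 to compound 4 (beyond the scatter).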

Compound 4, a percentage reported as activity, at one concentration (the size of the read-out at that concentration, not a potency): 18.6%
Estimate against measurement, compound 4: 6.6 percentage points below, within the range that was stated.
By their numbers in this assay, from the lowest: compound 2; then compounds 4 and 1 (each within the scatter of the next). At a limit, below all of these: compound 3.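

Replacing 4-bromophenyl on the sulfonyl sulfur with 3-ethynylphenyl gives, in this assay, a number 7 percentage points lower from compound 1 to compound 4 (within the scatter), so a triple bond outside the aromatic ring does not by itself produce a change that can be told apart from the bromo starting point. The earlier step with the cyclohexyl-capped alkyne reads a number 24.4 percentage points lower from compound 1 to compound 2 (beyond the scatter), which shows that the large move seen there is not reproduced by this bare ethynyl change. Compound 3 alone remains at a limit of the assay: the limit of < 1% in this assay, at which 1 of the 4 values shown sits.

Compound 4 differs from the capped alkynes both in having no cap on the triple bond and in the printed name of its aryl group, 3-ethynylphenyl, so these compounds cannot show which of the two matters. A 4-ethynylphenyl group would separate those two features, and a short capped alkyne such as prop-1-yn-1-yl or a chain with an amine at its end would show how much of the cap is needed on this sulfonamide aryl group.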